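The source may hold more compounds than are shown below. What is called first, only, known or untested is meant among the compounds shown, and "the series" means these compounds.

Compound 1 `N=C(N)NCCC[C@H](NC(=O)CN(c1nc(Cl)nc2[nH]cnc12)C1CC1)C(=O)O`: 17%
Compound 2 `O=C(OCc1ccccc1)[C@@H]1CCCN1C(=O)CN(c1nc(Cl)nc2[nH]cnc12)C1CC1`: 38.4%
Compound 3 `N=C(N)NCCC[C@H](NC(=O)CN(c1nc(Cl)nc2[nH]cnc12)C1CC1)C(=O)OCc1ccccc1`: 10.2%

All three were tested in a functional assay on the whole organism (Tail, strain ICR) with Mus musculus as the target, in the tail flick test, with a stated time of 120 min, at a dose of 25 umol/kg by the oral route; on this read-out higher numbers stand for a stronger effect at the one dose given and lower numbers for a weaker effect. Compound 1 stands second highest of the three numbers: compound 3 is nearest, with a number 6.8 percentage points lower from compound 1 to compound 3 (within the scatter), a change of benzyl in place of hydrogen on an oxygen next to a carbonyl group, and compound 2 is furthest, higher by an amount beyond the scatter. Compound 4 `NCCCC[C@H](NC(=O)CN(c1nc(Cl)nc2[nH]cnc12)C1CC1)C(=O)O` has not yet been measured. It differs from compound 1 in one place: a group of 2 heavy atoms (1 carbon, 1 nitrogen; no ring) in place of a group of 4 heavy atoms (1 carbon, 3 nitrogen; no ring), on a saturated chain carbon, four bonds along the chain from an amide-type nitrogen and a carbonyl carbon. For the measured compounds named here, no measured step alters this part of the structure, and the single step in hand concerns a different position and stayed within the scatter. Going by the values given here, with no step bearing on the change, compound 4 is expected to give no change at the digits printed from compound 1 to compound 4 (within the scatter) in this assay, that is, no movement beyond the scatter. Compound 4 is therefore estimated at 17%, with a range from 4% to 32%.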

Compound 4, a percentage reported as activity, at one dose (the size of the read-out at that dose, not a potency): 16.4%
Beside the measured number, compound 4's estimate is 0.6 percentage points above it; the range from low to high includes it.
By their numbers in this assay, from the lowest: compounds 3, 4 and 1 (each within the scatter of the next); then compound 2.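

In this assay, for the compounds shown here, this is the first reading at the far end of the saturated chain, and aminomethyl in place of the group of 4 heavy atoms gives a number 0.6 percentage points lower from compound 1 to compound 4 (within the scatter). The leaving group has 3 hydrogen-bond donors and aminomethyl has 1, yet this difference in count does not separate the two compounds at this one dose. Nothing measured here offers an explanation for this result. Going by these compounds, whether a hydroxyl group or a longer chain ending in an amine would read differently at this position remains open. So does how a benzyl ester would read alongside aminomethyl.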